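The source may hold more compounds than are shown below. What is called first, only, known or untested is meant among the compounds shown, and "the series" means these compounds.

For the measured compounds named here, compound 1 `Cc1ccc2c(=O)[nH]c(-c3ccccc3F)nc2c1` gives 81.2% in an assay on isolated protein for inhibition of DNA topoisomerase 1 (Homo sapiens), with a stated time of 30 min, tested at 100 uM (on this read-out lower numbers stand for a weaker effect and higher numbers for a stronger effect at the one concentration tested), the lowest of the three numbers measured so far. Compound 3 `CCN(CC)c1ccc2nc(-c3ccccc3C(F)(F)F)[nH]c(=O)c2c1` gives 81.7%, a number within the usual scatter of compound 1, so the two cannot be told apart. Compound 2 `Cc1ccc2c(=O)[nH]c(-c3cccc4ccccc34)nc2c1` gives 100%, which lies beyond the scatter above compound 1. The next compound, compound 4 `Cc1ccc2c(=O)[nH]c(-c3ccccc3C)nc2c1`, differs from compound 1 by a single exchange: methyl in place of fluoro on an aromatic carbon. Going by the values given here, no measured pair shows this exchange, so there is no step to lean on. Trading one heavy atom for one heavy atom, with no change in donors, acceptors or charge, is expected to move the number little, and the expected step of a number 0.8 percentage points higher from compound 1 to compound 4 (within the scatter) is none beyond the scatter. Compound 4 is therefore estimated to give about 82%, with a likely range from 65% to 95%.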

Compound 4, a percentage reported as inhibition, at one concentration (the size of the read-out at that concentration, not a potency): 100%
Compound 4: middle estimate off by 18 percentage points, on the low side; the whole stated range lies below it.
By their numbers in this assay, from the lowest: compounds 1 and 3 (each within the scatter of the next); then compounds 2 and 4 (each within the scatter of the next).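

Methyl in place of fluoro gives a number 18.8 percentage points higher from compound 1 to compound 4 (beyond the scatter) in this assay even though one heavy atom replaces one heavy atom and the counts of hydrogen-bond donors, acceptors and charge stay the same. This aromatic carbon is therefore not indifferent to which small group it carries. No measurement at hand accounts for the step.

Still open, as far as these compounds go, is how chloro, methoxy or an amine on the same carbon would compare with methyl and fluoro. Also open, from the compounds shown here alone, is whether this exchange would give a similar step elsewhere on that ring.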